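This account rests on a few compounds, and the source may have more. Where it says the series, first, only, none or still open, it means among the compounds named here.

Working notes on the series. In a functional assay on HeLa cells (Homo sapiens) for cytotoxicity, read by MTT assay, with a stated time of 72 h (a higher number here means a weaker inhibitor, a lower number a stronger inhibitor), compound 1 `COc1ccc(/C=C/C(=O)OC/C=C/c2ccc(OC)c(OC)c2)cc1` gives 167000 nM and compound 2 `COc1cc(/C=C/COC(=O)/C=C/c2cc(OC)c(OC)c(OC)c2)cc(OC)c1OC` gives 43000 nM. Compound 2 has the lower of these two numbers, and the gap between them lies beyond the scatter. For compound 3 `COCOc1ccc(/C=C/C(=O)OC/C=C/c2ccccc2)cc1OCOC`, this assay returns only a limit, > 1000000 nM. Among the measured compounds shown here, compound 2 therefore stands as the strongest inhibitor of the three so far, although only two of the readings are actual numbers.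

The next structure is compound 4 `COc1ccc(/C=C/COC(=O)/C=C/c2cc(OC)c(OC)c(OC)c2)cc1OC`. It differs from compound 2 by hydrogen in place of methoxy on an aromatic carbon, ortho to a methoxy group. For the measured compounds named here, no measured pair isolates this change, so its size in this assay cannot be read directly from the series. Going by the values given here, the only numerical guide is compound 1 at 167000 nM, the nearest value to compound 2. A modest rise in the number, meaning a somewhat weaker inhibitor, is expected, possibly not beyond the scatter. The expected step is a 1.9-fold higher number from compound 2 to compound 4 (0.27 log units; within the scatter). For compound 4 the estimated value is 80000 nM, with an expected range of 30000 nM to 220000 nM.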

Compound 4, half-maximal inhibitory concentration: 64000 nM
Beside the measured number, compound 4's estimate is 1.3-fold (0.10 log units) above it, and the stated range covers the measured number.
By their numbers in this assay, from the lowest: compounds 2 and 4 (each within the scatter of the next); then compound 1. At a limit, above all of these: compound 3.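

Hydrogen in place of methoxy on an aromatic carbon, ortho to a methoxy group and meta to a large group, now has a direct reading in this assay, with a 1.5-fold higher number from compound 2 to compound 4 (0.17 log units; within the scatter). The earlier compounds shown here differed in more than one place and could not isolate this position, whereas this pair shows that the methoxy group there is not needed to hold the reading within the scatter of the parent value, at least against the background of the shared core. The series still holds one compound without a number, since compound 3 stands at a limit of the assay: the limit of > 1000000 nM in this assay, at which 1 of the 4 values shown sits.

Among the compounds shown here, it remains open whether a different group at this position, such as a hydroxyl, an amine or a fluorine atom, would move the number beyond the scatter, since hydrogen and methoxy are the only two groups compared there. As far as these compounds go, it also remains open whether the same replacement at the other methoxy groups of the core would give a step of similar size, or whether an amide in place of the ester would shift the whole series.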